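Methyl for Methoxy: A Change Without a Measured Precedent

A few compounds are considered here, and "the series" means these few. Any claim that something is new, unique, unknown or untested is made for them only; others in the source may bear on it.

compound 1 `COc1ccc(C(/C=C/c2ccc(F)cc2)=N/O)cc1`: 11000 nM
compound 2 `COc1ccc(C(/C=C/c2ccc(Br)cc2)=N/O)cc1`: 13900 nM
compound 3 `COc1ccc(C(/C=C/c2ccccc2)=N/O)cc1`: 11800 nM

In a functional assay (Mus musculus, strain Balb/c) for inhibition, read by ELISA, with a stated time of 72 h (on this read-out higher numbers stand for weaker inhibition and lower numbers for stronger inhibition), the number for compound 2 is the largest of the three, yet every step among these compounds is small: a 1.3-fold higher number from compound 1 to compound 2 (0.10 log units; within the scatter), a 1.2-fold lower number from compound 2 to compound 3 (0.07 log units; within the scatter) and a 1.1-fold higher number from compound 1 to compound 3 (0.03 log units; within the scatter). The three compounds are therefore not told apart by this read-out, and no ranking among them is justified.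

Compound 4 `Cc1ccc(C(/C=C/c2ccc(Br)cc2)=N/O)cc1` differs from compound 2 by methyl in place of methoxy on an aromatic carbon. All three measured steps concern the other aromatic ring, where fluoro, bromo and hydrogen were exchanged; none of them touches the methoxy group. Among the measured compounds shown here, there is thus no measured step that bears on this change, and the expectation rests only on the fact that the ring in question has so far tolerated small exchanges without effect beyond the scatter. Compound 4 is expected to give 14000 nM in this assay, with a range from 6000 nM to 33000 nM, which means an expected step of a 1.0-fold higher number from compound 2 to compound 4 (0.00 log units; within the scatter), none beyond the scatter.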

Compound 4, half-maximal inhibitory concentration: 11600 nM
For compound 4 the middle estimate is 1.2-fold (0.08 log units) above the measured one; measured number inside the range.
By their numbers in this assay, from the lowest: compounds 1, 4, 3 and 2 (each within the scatter of the next).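

Compound 4 is the first compound shown in which the group on the methoxy-bearing ring is exchanged, and in this assay the exchange gives a 1.2-fold lower number from compound 2 to compound 4 (0.08 log units; within the scatter) and so cannot be told apart from no effect. Methoxy carries 1 hydrogen-bond acceptor and methyl carries 0, so in this one pair, the oxygen atom and that acceptor can be lost without a difference this read-out can detect. Nothing measured here explains this result. Still open, on these data alone, is whether this place would accept groups of another kind, such as an amine, a carboxylic acid or a longer chain like butoxy. As far as these compounds go, the exchange has also been read only with bromo on the other ring, so its outcome alongside fluoro or hydrogen there remains unknown.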